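Second methoxy on the aryl ring of compound 1

The source may hold more compounds than are shown below. What is called first, only, known or untested is meant among the compounds shown, and "the series" means these compounds.

Compound 1 `CCn1c(SCC(=O)c2ccccc2)nnc1-c1ccc(OC)cc1` is the reference point of this set. In a functional assay on the whole organism (strain albino) for inhibition, with Rattus norvegicus as the target, read by paw edema, with a stated time of 1 h, at a dose of 0.28 mmol/kg by the oral route (a higher number here means more inhibition at the dose given (going by the name of the read-out), a lower number less inhibition), compound 1 gives 53%, and the two other numbers sit within the scatter of it. Compound 2 `CCn1c(SCC(=O)c2ccccc2)nnc1-c1ccccc1` gives 52% in this assay, and the step of a number 1 percentage points lower from compound 1 to compound 2 (within the scatter) removes the methoxy group from the aromatic ring. Compound 3 `C=CCn1c(SCC(=O)c2ccccc2)nnc1-c1ccc(OC)cc1` gives 49%, and the step of a number 4 percentage points lower from compound 1 to compound 3 (within the scatter) changes the chain on the aromatic nitrogen.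

Compound 4 `CCn1c(SCC(=O)c2ccccc2)nnc1-c1ccc(OC)c(OC)c1` differs from compound 1 by methoxy in place of hydrogen on an aromatic carbon.

For the measured compounds named here, the step that bears on this change is the one from compound 1 to compound 2, which shows that the presence or absence of a methoxy group on this ring moves the read-out by an amount within the scatter. A second methoxy group on the same ring is therefore expected to leave the read-out in this assay unchanged beyond the scatter, with no direction favoured. Compound 4 is estimated at 51%, within 39% to 63%, a step of a number 2 percentage points lower from compound 1 to compound 4 (within the scatter) from the reference.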

Compound 4, a percentage reported as inhibition, in the whole organism at one dose (the size of the read-out at that dose, not a potency): 42%
Compound 4: middle estimate off by 9 percentage points, on the high side; measured number inside the range.
By their numbers in this assay, from the lowest: compounds 4, 3, 2 and 1 (each within the scatter of the next, the first and the last beyond it).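

In this assay, the ring position ortho to a methoxy group and meta to a large group does respond to substitution: a number 11 percentage points lower from compound 1 to compound 4 (beyond the scatter). For the compounds shown here, the earlier step of a number 1 percentage points lower from compound 1 to compound 2 (within the scatter) showed only that the single methoxy group could go without a change beyond the scatter, so the presence of a methoxy group on this ring does not by itself predict the outcome for a second one. No measurement available here accounts for the drop in inhibition.

As far as these compounds go, it remains open whether the new methoxy group would give a similar step on the unsubstituted ring of compound 2, where no methoxy group stands ortho to it. Also open, from the compounds shown here alone, is how a hydroxy group, a chlorine atom or an ethoxy group at this place would read, and whether the step would persist at other doses or times.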